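A few compounds are considered here, and "the series" means these few. Any claim that something is new, unique, unknown or untested is made for them only; others in the source may bear on it.

Measured compounds:
- Compound 1, `Nc1ncc(-c2nc3ccccc3s2)c(N[C@@H]2C[C@H](CO)[C@@H](O)[C@H]2O)n1`: in an ADME assay on cells (Homo sapiens) for cytotoxicity, read by polymerase chain reaction, with a stated time of 3 days (a lower number here means that less compound is tolerated, a higher number that more compound is tolerated), compound 1 gives > 25000 nM, which is a limit of the assay and not a number.
- Compound 2, `CCNc1nc(C)c(-c2nc3ccccc3s2)c(N[C@@H]2C[C@H](CO)[C@@H](O)[C@H]2O)n1`: in this assay compound 2 gives 12000 nM.

Compound 2 is the only one of the two whose result in this assay is a number. For the measured compounds named here, the other result sits at the limit, as the limit of > 25000 nM in this assay, at which 1 of the 2 values shown sits, states, so no measured step between the two can be given; the values show only that compound 2 was read out below the limit while compound 1 was not.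

Compound 3, `Cc1nc(NCC(C)C)nc(N[C@@H]2C[C@H](CO)[C@@H](O)[C@H]2O)c1-c1nc2ccccc2s1`, has not yet been measured in this assay. It differs from compound 2 in one place: isopropyl in place of methyl on a saturated chain carbon bound to a nitrogen on an aromatic ring. The change is small and sits on the chain bound to the ring nitrogen, away from the shared core and the rest of the molecule.

Going by the values given here, with no measured step of this kind to lean on, the expectation is that the step of a 1.2-fold lower number from compound 2 to compound 3 (0.08 log units; within the scatter) stays within the usual scatter of repeated measurements, with perhaps a slight lean towards less compound being tolerated. Compound 3 is therefore estimated at 10000 nM, with a range from 4000 nM to 25000 nM.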

Compound 3, half-maximal cytotoxic concentration: 10000 nM
For compound 3 middle estimate and measured number coincide at the digits printed, and the stated range covers the measured number.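

For the compounds shown here, replacing methyl with isopropyl, on a saturated chain carbon bound to a nitrogen on an aromatic ring, gives a 1.2-fold lower number from compound 2 to compound 3 (0.08 log units; within the scatter) in this assay, and this is the first step in the set that can be read between two numbers. It shows that, at this position, exchanging the ethylamino chain for the larger isobutylamino chain leaves no difference in this read-out that stands out from repeat-to-repeat variation, so this one change does not visibly alter how much compound the cells tolerate. Compound 1 remains a limit of the assay and not a number, so no step to it can be read: the limit of > 25000 nM in this assay, at which 1 of the 3 values shown sits.

What the compounds shown leave open is whether the same place would stay as indifferent to a group of a different kind, such as a carboxylic acid, a terminal amine on the chain or a much longer chain like n-octyl. A single step within the scatter also cannot tell whether the same exchange would read the same way on a different core.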